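Methoxyphenyl in place of difluorophenyl on the carbonyl

The compounds below may be only part of what the source reports. "The series", "measured", "known", "first", "only" and "open" are said of these compounds alone.

Measured so far:
compound 1 `COc1cc(-c2nnc3n2NC(c2ccco2)C(C(=O)c2ccccc2C)S3)cc(OC)c1OC` with 63000 nM
compound 2 `COc1cc(-c2nnc3n2NC(c2ccco2)C(C(=O)c2ccc(F)c(F)c2)S3)cc(OC)c1OC` with 52400 nM

In a functional assay on HepG2 cells (Homo sapiens) for cytotoxicity, read by MTT assay, with a stated time of 48 h (on this read-out lower numbers stand for stronger inhibition and higher numbers for weaker inhibition), compound 2 carries the lower of the two numbers, but its gap to compound 1 is within the scatter. Compound 3 `COc1cccc(C(=O)C2Sc3nnc(-c4cc(OC)c(OC)c(OC)c4)n3NC2c2ccco2)c1` differs from compound 2 by 3-methoxyphenyl in place of 3,4-difluorophenyl on a carbonyl carbon. Going by the values given here, the one step that bears on it, a 1.2-fold lower number from compound 1 to compound 2 (0.08 log units; within the scatter), also exchanged the aryl group on that carbonyl carbon and stayed within the scatter, so no step beyond the scatter is expected in this assay here. Compound 3 is therefore estimated at 55000 nM in this assay, between 25000 nM and 120000 nM, an expected step of a 1.0-fold higher number from compound 2 to compound 3 (0.02 log units; within the scatter).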

Compound 3, half-maximal inhibitory concentration: > 100000 nM
Compound 3: only a limit was reported; the forecaster's own chance of this, stated with the estimate: 10%; at least 1.8-fold (0.25 log units) between middle value and limit.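

In this assay compound 3 gives only a limit, not a number: the limit of > 100000 nM in this assay, at which 1 of the 3 values shown sits. The steps are an at least 1.9-fold higher number from compound 2 to compound 3 (0.28 log units; that floor lies within the scatter) and an at least 1.5-fold higher number from compound 1 to compound 3 (0.20 log units; that floor lies within the scatter), so neither floor establishes a real change. Unlike the step between compound 1 and compound 2, this exchange on the carbonyl carbon, to the only aryl group here with a hydrogen-bond acceptor, has no upper bound on its size.

Still open, going by these compounds, is how large the loss is, if there is one. Also open, on these data alone, is whether 4-methoxyphenyl or an aminophenyl group on this carbonyl carbon would give a measurable number.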